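The source may hold more compounds than are shown below. What is called first, only, known or untested is meant among the compounds shown, and "the series" means these compounds.

Working notes on the series. Three compounds carry a number in a functional assay for agonist activity at G protein-coupled receptor 88 (Homo sapiens), read by HTRF and cAMP accumulation; on this read-out lower numbers stand for an effect already at smaller amounts and higher numbers for an effect only at larger amounts of compound. Compound 1 `CC[C@@H](C)[C@H](N)CN(C(=O)[C@@H]1C[C@H]1c1ccccc1)c1ccc(-c2ccccc2)cc1` gives 1.4 nM in this assay. Compound 2 `CC(C)C[C@H](N)CN(C(=O)[C@@H]1C[C@H]1c1ccccc1)c1ccccc1-c1ccccc1` gives 6200 nM. Compound 3 `CC[C@H](C)[C@H](N)CN(C(=O)[C@@H]1C[C@H]1c1ccccc1)c1ccc(-c2ccc(OC(C)C)cc2)cc1` gives 72 nM, the second highest of the three numbers: compound 1 sits far lower and compound 2 far higher, both gaps beyond the scatter. No two of these compounds differ in one place only, so the numbers are read side by side without a counted step between them.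

Compound 4 `CC[C@H](C)[C@H](N)CN(C(=O)[C@@H]1C[C@H]1c1ccccc1)c1ccc(-c2ccc(CN)cc2)cc1` is not yet measured. It differs from compound 3 in one place: aminomethyl in place of isopropoxy on an aromatic carbon The rest of the structure, including the amide, the cyclopropane and the stereocentres, is unchanged.

Within the data shown here, the series gives no measured pair that would show what an exchange of this kind does. The expected step from compound 3 to compound 4 is therefore small, a 1.7-fold higher number from compound 3 to compound 4 (0.22 log units; within the scatter), with a slight lean toward a higher number and no confidence that it leaves the scatter. In this assay compound 4 is expected at about 120 nM, in a range from 25 nM to 600 nM.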

Compound 4, half-maximal effective concentration: > 30000 nM
Compound 4: a limit, no number; the forecaster's own chance of this, stated with the estimate: 5%; middle value at least 250-fold (2.39 log units) from the limit.
By their numbers in this assay, from the lowest: compound 1; then compound 3; then compound 2. At a limit, above all of these: compound 4.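

At this place, on an aromatic carbon para to a large group, the series now has its first counted step: in this assay, aminomethyl in place of isopropoxy gives an at least 410-fold higher number from compound 3 to compound 4 (2.61 log units; beyond the scatter). Where compound 3 alone showed that this place can carry isopropoxy and keep 72 nM, this single exchange shows that a change here can take a compound out of the measurable range altogether. For compound 4 the result is a limit of the assay and not a number: the limit of > 30000 nM in this assay, at which 1 of the 4 values shown sits.

Open, as far as these compounds go, is whether the loss follows the entering amine or the departing isopropoxy, which a hydroxymethyl, a methoxy or a dimethylaminomethyl group at the same place could separate. Compound 1, with no group at this place, also differs from compound 3 at a stereocentre, so the effect of an empty position cannot be read from it.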